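Pyridine-side chain variation: a terminal pyrrolidine on the sulfanyl chain

A few compounds are considered here, and "the series" means these few. Any claim that something is new, unique, unknown or untested is made for them only; others in the source may bear on it.

Measured so far:
compound 1 `CCOc1nc(C(C)(C)C)ccc1CNC(=O)C(C)c1ccc(NS(C)(=O)=O)c(F)c1` 14.8 nM
compound 2 `CCCCSc1nc(C(C)(C)C)ccc1CNC(=O)C(C)c1ccc(NS(C)(=O)=O)c(F)c1` 3.2 nM

For the measured compounds named here, compound 2 holds the lower of the two numbers in an assay on cells for antagonist activity at transient receptor potential cation channel subfamily V member 1 (Homo sapiens), read by FLIPR and calcium flux, with a stated time of 6 min; a higher number here means a weaker inhibitor, a lower number a stronger inhibitor; its only neighbour, compound 1, sits well above it, the step being a 4.6-fold lower number from compound 1 to compound 2 (0.67 log units; beyond the scatter), a butylsulfanyl in place of ethoxy on an aromatic carbon.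

Compound 3 `CC(C(=O)NCc1ccc(C(C)(C)C)nc1SCCCN1CCCC1)c1ccc(NS(C)(=O)=O)c(F)c1` is not yet measured. Relative to compound 2 the change is pyrrolidin-1-yl in place of methyl on a saturated chain carbon, three bonds along the chain from a sulfur.

Going by the values given here, no measured step touches the chain end; the single step concerns the link to the aromatic carbon and says nothing about what a ring at the chain terminus does. The expectation therefore stays close to compound 2, with wide bounds on either side. For compound 3 the estimated value in this assay is 10 nM, range 2.5 nM to 40 nM, which means an expected step of a 3.1-fold higher number from compound 2 to compound 3 (0.49 log units; beyond the scatter).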

Compound 3, inhibition constant: 17.1 nM
Estimate against measurement, compound 3: 1.7-fold (0.23 log units) below; low and high end bracket the measured number.
By their numbers in this assay, from the lowest: compound 2; then compounds 1 and 3 (each within the scatter of the next).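

In this assay the end of the sulfanyl chain is not a silent position: pyrrolidin-1-yl in place of methyl on a saturated chain carbon, three bonds along the chain from a sulfur, gives a 5.3-fold higher number from compound 2 to compound 3 (0.73 log units; beyond the scatter), so a change at the chain terminus moves the number about as far as the change of link did. Measured against the ethoxy compound, the full (3-(pyrrolidin-1-yl)propyl)sulfanyl group shows a 1.2-fold higher number from compound 1 to compound 3 (0.06 log units; within the scatter), which leaves the two groups unseparated in this read-out and none of the advantage of butylsulfanyl retained. Nothing available accounts for this step.

The compounds shown leave open whether the ring or the amine nitrogen carries the change, which a terminal dimethylamino group or a morpholine ring on the same chain would address. Also open, as far as these compounds go, is how a shorter 2-(pyrrolidin-1-yl)ethyl chain or a longer chain would compare.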